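The source may report more compounds than this note shows. Statements on the series, on what has been measured and on what is new or still open speak of the compounds shown alone.

Compound 3 `CCOc1ccc2nc(C(=O)Nc3c(F)cc(-c4cccc(F)c4)cc3F)c(C)c(C(=O)O)c2c1` holds the highest of the three numbers, a spread that lies entirely within the scatter. In a functional assay on Hep 3B2 cells (Homo sapiens) for antiproliferative activity, read by MTT assay, with a stated time of 24 h, tested at 0.01 ug/mL (a lower number here means a weaker effect, a higher number a stronger effect of the compound at the concentration tested), compound 3 gives -0.12%, while compound 1 `CCc1ccc2nc(C(=O)Nc3c(F)cc(-c4cccc(F)c4)cc3F)c(C)c(C(=O)O)c2c1` gives -0.25% and compound 2 `Cc1c(C(=O)Nc2c(F)cc(-c3cccc(F)c3)cc2F)nc2ccc(F)cc2c1C(=O)O` gives -0.35%. The three steps among them are all small: a number 0.1 percentage points lower from compound 1 to compound 2 (within the scatter), a number 0.1 percentage points higher from compound 1 to compound 3 (within the scatter) and a number 0.2 percentage points higher from compound 2 to compound 3 (within the scatter). Compound 4 `Cc1c(C(=O)Nc2c(F)cc(-c3cccc(F)c3)cc2F)nc2ccc(C(F)(F)F)cc2c1C(=O)O` differs from compound 3 in one place: trifluoromethyl in place of ethoxy on an aromatic carbon. All three measured steps change the group at this same aromatic carbon, and none of them moves the read-out beyond the scatter, so no step beyond the scatter is expected in this assay, in either direction. Compound 4 is therefore expected to give about -0.2%, in a range from -3% to 3%, which means an expected step of a number 0.1 percentage points lower from compound 3 to compound 4 (within the scatter).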

Compound 4, a percentage reported as inhibition, at one concentration (the size of the read-out at that concentration, not a potency): 0.2%
The estimate for compound 4 lay 0.4 percentage points below the measured number, within the range that was stated.
By their numbers in this assay, from the lowest: compounds 2, 1, 3 and 4 (each within the scatter of the next).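

In this assay, trifluoromethyl, a fourth group at this aromatic carbon, also leaves the read-out within the scatter: a number 0.3 percentage points higher from compound 3 to compound 4 (within the scatter), a number 0.6 percentage points higher from compound 2 to compound 4 (within the scatter) and a number 0.5 percentage points higher from compound 1 to compound 4 (within the scatter). For the compounds shown here, with ethyl, fluoro, ethoxy and trifluoromethyl at this position, no step goes beyond the scatter, so this single concentration does not tell the four compounds apart. Nothing measured here bears on why the read-out stays flat. Going by these compounds, whether an amine, a carboxylic acid or a longer chain at this carbon would move the read-out beyond the scatter stays open. So does how these four compounds compare at other concentrations.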